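The compounds below may be only part of what the source reports. "The series", "measured", "known", "first", "only" and "open" are said of these compounds alone.

Measured in a functional assay on A549/CDDP cells (Homo sapiens) for antiproliferative activity, read by MTT assay, with a stated time of 72 h; on this read-out lower numbers stand for stronger inhibition and higher numbers for weaker inhibition:
Compound 1 `Cc1nc(C)c(/C=C/C(=O)/C=C/c2cccc(O)c2)nc1C`: 3700 nM
Compound 2 `Cc1nc(C)c(/C=C/C(=O)/C=C/c2ccc(F)cc2)nc1C`: 7440 nM

Among the compounds with values here, compound 1 stands level with compound 2, the only other measured compound, as their two values lie within the scatter of each other. Compound 3 `Cc1nc(C)c(/C=C/C(=O)/C=C/c2cccc([N+](=O)[O-])c2)nc1C` keeps the core of compound 1 and differs from it by one exchange, nitro in place of hydroxy on an aromatic carbon. Within the data shown here, no measured compound carries a nitro group, so the data do not show this exchange directly. Among the measured compounds shown here, the one measured step that bears on it also removes the hydroxy group, with 4-fluorophenyl in place of 3-hydroxyphenyl: a 2.0-fold higher number from compound 1 to compound 2 (0.30 log units; within the scatter). A step beyond the scatter is therefore not expected in this assay. The expected change is a 1.4-fold higher number from compound 1 to compound 3 (0.13 log units; within the scatter). For compound 3 the estimated value is 5000 nM, with an expected range of 2000 nM to 12000 nM.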

Compound 3, half-maximal inhibitory concentration: 6690 nM
Estimate against measurement, compound 3: 1.3-fold (0.13 log units) below; measured number inside the range.
By their numbers in this assay, from the lowest: compounds 1, 3 and 2 (each within the scatter of the next).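

In this assay, nitro in place of hydroxy gives a 1.8-fold higher number from compound 1 to compound 3 (0.26 log units; within the scatter) on this aromatic carbon, meta to a large group. The earlier step changed both the group and its place on the ring, whereas here the place stays the same and only the group differs, so the loss of the hydrogen-bond donor of hydroxy at this carbon leaves the number within the scatter. Nothing at hand accounts for this result.

The compounds shown leave open whether an amine or a carboxylic acid on this same aromatic carbon would also stay within the scatter of compound 1, or would give a step beyond it. They also leave open whether hydroxy and nitro would stand level on the other carbons of this ring.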